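The compounds below may be only part of what the source reports. "The series", "measured", "known", "first", "only" and "open" are said of these compounds alone.

In a functional assay on HCT-116 cells (Homo sapiens) for inhibition (a lower number here means a stronger inhibitor, a higher number a weaker inhibitor), compound 1 `CC(C)=CC(=O)OCc1cc(=O)oc2ccc(Cl)cc12` gives > 10 ug/mL, which is a limit and not a number. Compound 2 `COc1ccc2c(COC(=O)C=C(C)C)cc(=O)oc2c1` also gives only a limit, > 10 ug/mL. Compound 3 `C/C=C/C(=O)OCc1cc(=O)oc2cc(OC)c(OC)cc12` gives the limit > 10 ug/mL as well, so it has no exact value from which to measure a change. Compound 4 `COc1cc2oc(=O)cc(COC(=O)/C=C/c3ccc(Cl)cc3)c2cc1OC` has 4-chlorophenyl in place of methyl on a double-bonded chain carbon bound to a double-bonded chain carbon. Among the measured compounds shown here, no measured step offers a guide, so only a modest move towards stronger inhibition is expected, possibly none beyond the scatter, and the expected step is an at least 1.2-fold lower number from compound 3 to compound 4 (0.09 log units; that floor lies within the scatter). Compound 4 is estimated at 8 ug/mL, with an expected range of 3 ug/mL to 15 ug/mL.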

Compound 4, half-maximal inhibitory concentration: > 10 ug/mL
Compound 4 was reported as a limit; the forecaster's own chance of this, stated with the estimate: 55%; at least 1.2-fold (0.09 log units) between middle value and limit.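

Compound 3 and compound 4 are both reported only as limits in this assay, so no step can be read between them. How strongly any of these compounds inhibits stays open, because all share one limit: the limit of > 10 ug/mL in this assay, at which 4 of the 4 values shown sit.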